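The source may report more compounds than this note shows. Statements on the series, on what has been measured and on what is new or still open speak of the compounds shown alone.

Of the compounds shown here, two have been measured in an ADME assay on microsomes from liver (Homo sapiens) for metabolic stability, tested at 2.5 uM; a higher number here means faster removal of the compound, a lower number slower removal. Compound 1 `COc1ccc(S(=O)(=O)c2cnc3c(F)cccc3c2-c2ccc(Cl)cc2)cc1` gives 1.05 mL/min. Compound 2 `O=S(=O)(c1cccc(F)c1)c1cnc2c(F)cccc2c1-c1cccc(Cl)c1` gives 0.56 mL/min, the lower of the two numbers, though its gap to compound 1 lies within the scatter, so no order between them can be claimed. Compound 3 `COc1ccc(S(=O)(=O)c2cnc3c(F)cccc3c2-c2cccc(Cl)c2)cc1` is not yet measured; it differs from compound 2 by 4-methoxyphenyl in place of 3-fluorophenyl on a sulfonyl sulfur. Because compound 1 gives 1.05 mL/min with this same 4-methoxyphenyl on the sulfonyl sulfur, a modest upward step is expected, a 1.6-fold higher number from compound 2 to compound 3 (0.21 log units; within the scatter), possibly within the scatter. Compound 3 is therefore estimated at 0.9 mL/min, between 0.45 mL/min and 1.8 mL/min.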

Compound 3, intrinsic clearance in a liver preparation (reported as CLH), per the amount of preparation that the assay uses: 2.75 mL/min
Compound 3: middle estimate off by 3.1-fold (0.49 log units), on the low side; measured number outside the range, above it.
By their numbers in this assay, from the lowest: compounds 2 and 1 (each within the scatter of the next); then compound 3.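

In this assay, with 3-chlorophenyl held fixed, 4-methoxyphenyl in place of 3-fluorophenyl on a sulfonyl sulfur gives a 4.9-fold higher number from compound 2 to compound 3 (0.69 log units; beyond the scatter), so the group on this sulfur can change how fast the compound is removed. With 4-methoxyphenyl held fixed, 3-chlorophenyl in place of 4-chlorophenyl on an aromatic carbon gives a 2.6-fold higher number from compound 1 to compound 3 (0.42 log units; beyond the scatter), so the chlorine's place counts too. Still open, as far as these compounds go, is how other groups on the sulfonyl sulfur, such as a plain phenyl or a pyridine ring, would compare. Nothing available here explains either step.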